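Sulfopropyl on the Amine: a Predicted Loss of Affinity

A few compounds are considered here, and "the series" means these few. Any claim that something is new, unique, unknown or untested is made for them only; others in the source may bear on it.

Compound 1 `NC[C@@H]1CCCc2cc(S(=O)(=O)c3cccc(F)c3)ccc21` gives the lowest of the two numbers at hand in an assay on isolated protein for displacement of a labelled ligand from 5-hydroxytryptamine receptor 6 (Homo sapiens) (on this read-out higher numbers stand for weaker inhibition and lower numbers for stronger inhibition), with 0.0794 nM. Its nearest neighbour, compound 2 `CNC[C@@H]1CCCc2cc(S(=O)(=O)c3cc[nH]c3)ccc21`, gives 0.159 nM in this assay, a gap that lies within the scatter, so the two cannot be ranked against each other. Within the data shown here, no step between measured compounds connects them, since they differ in more than one place.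

Compound 3 `O=S(=O)(O)CCCNC[C@@H]1CCCc2cc(S(=O)(=O)c3cccc(F)c3)ccc21` is not yet measured. Its difference from compound 1 is 3-sulfopropyl in place of hydrogen on an amine nitrogen. Among the measured compounds shown here, nothing among the measured compounds carries a substituent of this kind, so the expectation rests on the size of the group that enters and on the place where it sits.

For compound 3 he expects a step of a 25-fold higher number from compound 1 to compound 3 (1.40 log units; beyond the scatter) in this assay, toward weaker inhibition. His estimate for compound 3 is 2 nM, with a range from 0.3 nM to 15 nM.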

Compound 3, inhibition constant: 1.26 nM
Beside the measured number, compound 3's estimate is 1.6-fold (0.20 log units) above it; measured number inside the range.
By their numbers in this assay, from the lowest: compounds 1 and 2 (each within the scatter of the next); then compound 3.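

Among these compounds, until now no step at this amine nitrogen had been available. In this assay, 3-sulfopropyl in place of hydrogen gives a 16-fold higher number from compound 1 to compound 3 (1.20 log units; beyond the scatter) and is a large change, yet compound 3 still gives 1.26 nM with the whole group attached, so a substituent of this size on the nitrogen does not abolish binding. Nothing measured here bears on the reason for this step.

The compounds shown leave open whether the step follows the sulfonic acid or the propyl chain that carries it: a plain propyl, or a carboxylic acid on a chain of similar length, on the amine of compound 1 would separate the two. They also leave open whether 3-sulfopropyl would cost as much on the amine of compound 2, which already carries a methyl.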